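A few compounds are considered here, and "the series" means these few. Any claim that something is new, unique, unknown or untested is made for them only; others in the source may bear on it.

Measured compounds in a functional assay on MDA-MB-435 cells (Homo sapiens) for inhibition, read by sulforhodamine B assay, with a stated time of 48 h; a higher number here means a weaker inhibitor, a lower number a stronger inhibitor:
Compound 1 `COc1cc(-c2nn(-c3cccc(NC(=O)Nc4cc(C(F)(F)F)cc(C(F)(F)F)c4)c3)cc2-c2ccncc2)ccc1Cl`: 890 nM
Compound 2 `COc1cc(-c2nn(-c3cccc(NC(=O)Nc4ccc(Cl)c(Cl)c4)c3)cc2-c2ccncc2)ccc1Cl`: 940 nM
Compound 3 `O=C(Nc1cccc(-n2cc(-c3ccncc3)c(-c3ccc(Cl)c(O)c3)n2)c1)Nc1ccc(Cl)c(Cl)c1`: 1100 nM

Compound 2 holds the second highest of the three numbers in this assay, and all three values sit close together. Compound 1 gives 890 nM, and compound 2 gives 940 nM; the two numbers lie within the usual scatter of each other, so no order can be read between them. Among the measured compounds shown here, the one step that is measured runs a 1.2-fold higher number from compound 2 to compound 3 (0.07 log units; within the scatter), and it too stays within the scatter.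

Compound 4 `COc1cc(-c2nn(-c3cccc(NC(=O)Nc4ccc(Cl)c(C(F)(F)F)c4)c3)cc2-c2ccncc2)ccc1Cl` is not yet measured. It differs from compound 2 by trifluoromethyl in place of chloro on an aromatic carbon, the same difference cut one bond further out reading 3,4-dichlorophenyl to 4-chloro-3-(trifluoromethyl)phenyl. For the measured compounds named here, no measured step covers this change directly. The nearest guide is the pair of compound 1 and compound 2, whose two values in this assay differ by an amount within the scatter, and the step from compound 2 to compound 3 on a different part of the molecule also stays within the scatter. For compound 4 the expected step in this assay is therefore a 1.0-fold lower number from compound 2 to compound 4 (0.01 log units; within the scatter), a move of no size beyond the scatter in either direction. The estimate for compound 4 is 920 nM, expected to fall between 450 nM and 1900 nM.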

Compound 4, half-maximal inhibitory concentration: 680 nM
Compound 4: middle estimate off by 1.4-fold (0.13 log units), on the high side; the measured number falls inside the stated range.
By their numbers in this assay, from the lowest: compounds 4, 1, 2 and 3 (each within the scatter of the next).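

In this assay, putting trifluoromethyl in place of chloro, on an aromatic carbon ortho to a chloro group and meta to a large group, gives a 1.4-fold lower number from compound 2 to compound 4 (0.14 log units; within the scatter). This is the first single-place change shown on this ring, whereas the earlier step, a 1.2-fold higher number from compound 2 to compound 3 (0.07 log units; within the scatter), lies on another part of the molecule. At this position, then, a group of 4 heavy atoms can replace a group of 1 heavy atom with no move beyond the scatter, so this one exchange gives no sign that the read-out depends on which of the two groups sits there.

Still open, from the compounds shown here alone, is whether an amine, a carboxylic acid or a nitrile on this same carbon would also stay within the scatter of compound 2, and whether the exchange would give a similar step in the hydroxy series of compound 3. No measurement at hand offers any explanation for the result.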